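The compounds below may be only part of what the source reports. "The series", "measured", "known", "first", "only" and "open" are said of these compounds alone.

Measured so far:
Compound 1, `CN(C)c1ccc(C2CC(c3ccc(-n4ccnc4)cc3)=NN2)cc1`: -20.9%
Compound 2, `CC(=O)N1N=C(c2ccc(-n3cncn3)cc2)CC1c1ccc(N(C)C)cc1`: 11%

In a functional assay on HCC1806 cells (Homo sapiens) for inhibition, read by sulforhodamine B assay, tested at 10 uM (a lower number here means less inhibition, a higher number more inhibition at the concentration tested (going by the name of the read-out)), compound 1 gives -20.9%, while compound 2 gives 11%. Compound 2 thus stands highest of the two numbers; its nearest neighbour is compound 1, whose number lies lower by a gap beyond the usual scatter. Among the compounds with values here, these two compounds differ in more than one place, so no single step between measured compounds is known.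

Compound 3, `CC(=O)N1N=C(c2ccc(-n3ccnc3)cc2)CC1c1ccc(N(C)C)cc1`, has not yet been measured in this assay. It differs from compound 2 in one place: 1H-imidazol-1-yl in place of 1H-1,2,4-triazol-1-yl on an aromatic carbon. Within the data shown here, compound 1 also carries the 1H-imidazol-1-yl group, but it differs from compound 3 elsewhere too, so the two measured values give no isolated step for this exchange. The step expected for compound 3 is small, a slight drop or none beyond the scatter: a number 6 percentage points lower from compound 2 to compound 3 (within the scatter). Compound 3 is accordingly estimated at 5%, with a range from -20% to 25%.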

Compound 3, a percentage reported as inhibition, at one concentration (the size of the read-out at that concentration, not a potency): -9.7%
The estimate for compound 3 lay 14.7 percentage points above the measured number, and the stated range covers the measured number.
By their numbers in this assay, from the lowest: compound 1; then compound 3; then compound 2.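

In this assay, 1H-imidazol-1-yl in place of 1H-1,2,4-triazol-1-yl on the aromatic carbon gives a number 20.7 percentage points lower from compound 2 to compound 3 (beyond the scatter), which shows that this position responds to the exchange while the acetyl group and the rest of the structure stay the same. Within the data shown here, with 1H-imidazol-1-yl held fixed, acetyl in place of hydrogen on the ring amine nitrogen gives a number 11.2 percentage points higher from compound 1 to compound 3 (beyond the scatter), the first step that isolates a change at that nitrogen. Nothing available explains either step.

The compounds shown leave open how a pyrazol-1-yl ring, an amine or a carboxylic acid would fare at the aromatic carbon. They also leave open whether a longer acyl chain, such as propanoyl, on the ring nitrogen would extend or reverse the step seen with acetyl.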